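Methoxy in place of hydrogen on the anilino ring of compound 1

A few compounds are considered here, and "the series" means these few. Any claim that something is new, unique, unknown or untested is made for them only; others in the source may bear on it.

Compound 1 `Cc1nc(SCC(=O)Nc2nc(-c3ccc(Cl)cc3)cs2)n(Nc2ccccc2)c1C` carries a chlorine on one phenyl ring and an unsubstituted anilino group on the shared core. In a functional assay on 786-0 cells (Homo sapiens) for antiproliferative activity, read by sulforhodamine B assay, with a stated time of 48 h (on this read-out lower numbers stand for stronger inhibition of growth and higher numbers for weaker inhibition of growth), compound 1 gives 13700 nM. Within the data shown here, that is the only finished number in this small set. The set also holds compound 2 `Cc1ccc(Nn2c(SCC(=O)Nc3nc(-c4ccccc4)cs3)nc(C)c2C)cc1`, but for compound 2 the result in this assay is a limit of the assay, > 100000 nM (the limit of > 100000 nM in this assay, at which 1 of the 2 values shown sits). Among the measured compounds shown here, compound 2 differs from compound 1 in more than one place, so the two values show only that compound 1 gave a number where compound 2 did not.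

Compound 3 `COc1ccc(Nn2c(SCC(=O)Nc3nc(-c4ccc(Cl)cc4)cs3)nc(C)c2C)cc1` keeps the chlorophenyl of compound 1 and differs from it in a single place: methoxy in place of hydrogen on an aromatic carbon. For the measured compounds named here, no measured pair shows this change, so the size of the step is open. The step from compound 1 to compound 3 is expected to be small, a 1.5-fold higher number from compound 1 to compound 3 (0.16 log units; within the scatter), with no clear direction beyond the scatter. Compound 3 is therefore estimated at 20000 nM, within a range from 5000 nM to 100000 nM.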

Compound 3, concentration for total growth inhibition: 18200 nM
For compound 3 the middle estimate is 1.1-fold (0.04 log units) above the measured one, within the range that was stated.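

Methoxy in place of hydrogen on the anilino ring gives, in this assay, a 1.3-fold higher number from compound 1 to compound 3 (0.12 log units; within the scatter), so the two compounds cannot be told apart on this read-out. Among these compounds, this is the first single change in the set whose size can be read, and it shows that with methoxy on this aromatic carbon, para to a large group, the chlorophenyl series still gives a finished number rather than a limit of the assay. The compounds shown offer no measured reason for the size of this step.

One group at one place cannot say whether other groups there, such as a chlorine, a nitrile, an amine or a carboxylic acid, would also stay within the scatter, or whether methoxy would do so on another carbon of the anilino ring. The compounds shown also hold no pair that differs only in the chlorine of the chlorophenyl ring, so what that atom contributes on this read-out stays open.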